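Swapping Phenyl for a Naphthyloxymethyl Arm on the Oxadiazole

The source may hold more compounds than are shown below. What is called first, only, known or untested is meant among the compounds shown, and "the series" means these compounds.

Compound 1 `O=c1c(-c2nnc(COc3ccc4ccccc4c3)o2)cn(C2CC2)c2cc(N3CCNCC3)c(F)cc12`: 16 ug/mL
Compound 2 `O=c1c(-c2nnc(-c3ccccc3)o2)cn(C2CC2)c2cc(N3CCNCC3)c(F)cc12`: 46 ug/mL
Compound 3 `CCn1cc(-c2nnc(-c3ccccc3)o2)c(=O)c2cc(F)c(N3CCNCC3)cc21`: 112 ug/mL

Of the compounds shown here, three sharing one core have been tested in a functional assay on A549 cells (Homo sapiens) for cytotoxicity, read by MTT assay; on this read-out lower numbers stand for stronger inhibition and higher numbers for weaker inhibition. Compound 2 gives the second highest number of the three; compound 3 sits nearer to it, with compound 1 the furthest away and the lowest number of the set.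

Compound 4 `O=c1c(-c2nnc(COc3cccc4ccccc34)o2)cn(C2CC2)c2cc(N3CCNCC3)c(F)cc12` has not yet been measured. It differs from compound 2 in one place: ((naphthalen-1-yl)oxy)methyl in place of phenyl on an aromatic carbon.

Going by the values given here, only one measured step speaks to this change. Going the other way, replacing a ((naphthalen-2-yl)oxy)methyl arm with a plain phenyl, produced a 2.9-fold higher number from compound 1 to compound 2 (0.46 log units; beyond the scatter) in this assay. Compound 4 carries the closely related ((naphthalen-1-yl)oxy)methyl arm, an isomer that attaches through a different ring position; how that isomer behaves has not been measured, so the direction is taken from compound 1 and the size is held somewhat loosely. A drop in the number beyond the scatter is therefore expected, roughly mirroring the step from compound 1 to compound 2.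

For compound 4 the expected outcome in this assay is 20 ug/mL, with a likely range from 9 ug/mL to 45 ug/mL, which amounts to an expected step of a 2.3-fold lower number from compound 2 to compound 4 (0.36 log units; beyond the scatter).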

Compound 4, half-maximal inhibitory concentration: 96.2 ug/mL
Beside the measured number, compound 4's estimate is 4.8-fold (0.68 log units) below it; measured number outside the range, above it.
By their numbers in this assay, from the lowest: compound 1; then compound 2; then compounds 4 and 3 (each within the scatter of the next).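

The new result shows that adding a large arm at this position does not by itself lower the number in this assay: placing the ((naphthalen-1-yl)oxy)methyl arm on the aromatic carbon of the five-membered ring in place of phenyl gives a 2.1-fold higher number from compound 2 to compound 4 (0.32 log units; beyond the scatter), whereas the closely related arm of compound 1 stands on the lower side of phenyl, as a 2.9-fold higher number from compound 1 to compound 2 (0.46 log units; beyond the scatter) shows. The two arms differ only in which ring position of the naphthalene carries the oxygen, yet naphthalen-1-yl in place of naphthalen-2-yl gives a 6.0-fold higher number from compound 1 to compound 4 (0.78 log units; beyond the scatter), so the activity at this position depends on that attachment as well as on the size of the group. The compounds shown offer no independent information on why these two isomers differ.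

As far as these compounds go, a phenoxymethyl arm would help separate the contribution of the oxymethyl chain from that of the second aromatic ring, and it remains open how far that chain alone moves the number. From the compounds shown here alone, it also remains open whether an ethyl group on the ring nitrogen would shift the number in the same way in compounds carrying either naphthalene arm as it does in the phenyl pair.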